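Cytotoxicity in MT4 cells: from cyanomethyl to 2-chlorobenzyl

A few compounds are considered here, and "the series" means these few. Any claim that something is new, unique, unknown or untested is made for them only; others in the source may bear on it.

Measured compounds:
compound 1 `O=C1N(Cc2cccc(Cl)c2)c2cccn2S(=O)(=O)N1Cc1cccc(F)c1` — 208000 nM
compound 2 `O=C1N(Cc2ccccc2)c2cccn2S(=O)(=O)N1Cc1cccc(F)c1` — > 288000 nM
compound 3 `N#CCN1C(=O)N(Cc2ccccc2)S(=O)(=O)c2cscc21` — 503000 nM

In an ADME assay on MT4 cells (Homo sapiens) for cytotoxicity, read by MTT assay, with a stated time of 5 days (a lower number here means that less compound is tolerated, a higher number that more compound is tolerated), compound 3 gives the highest of the two numbers obtained; compound 1 is the nearest, and its lower number lies beyond the scatter. Compound 2 is reported only as a limit of this assay the limit of > 288000 nM in this assay, at which 1 of the 3 values shown sits, and not as a number.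

Compound 4 `O=C1N(Cc2ccccc2Cl)c2cscc2S(=O)(=O)N1Cc1ccccc1` is reached from compound 3 by the change (2-chlorophenyl in place of cyano on a saturated chain carbon bound to an amide-type nitrogen in a ring). Among the compounds with values here, the only measured step, an at least 1.3-fold higher number from compound 1 to compound 2 (0.14 log units; that floor lies within the scatter), concerns hydrogen in place of chloro on an aromatic carbon, a small move that sits within the scatter; it touches neither cyano nor 2-chlorophenyl and so bears only loosely on the present change. Within the data shown here, with no step of the same kind measured, compound 4 is expected to sit near compound 3, with a modest downward move, a 2.0-fold lower number from compound 3 to compound 4 (0.30 log units; within the scatter), judged likely but not assured to exceed the scatter.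

For compound 4 the estimated value in this assay is 250000 nM, with a range from 100000 nM to 550000 nM.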

Compound 4, half-maximal cytotoxic concentration: > 119000 nM
Compound 4: only a limit was reported; the forecaster's own chance of this, stated with the estimate: 40%; the middle value is on the limit's open side.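

Compound 4 is reported only as a limit and not as a number, so the step from compound 3 to compound 4 cannot be read: the limit of > 119000 nM in this assay, at which 1 of the 4 values shown sits. The compounds shown leave open how far the change from cyanomethyl to 2-chlorobenzyl shifts the result in this assay.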